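The source may report more compounds than this note shows. Statements on the series, on what has been measured and on what is new or still open speak of the compounds shown alone.

Measured compounds and their values:
Compound 1, `CN(C)CCn1cc(S(=O)(=O)c2ccccc2)c2cccnc21`, 25 nM.
Compound 2, `CN(C)CCn1cc(S(=O)(=O)c2c(Cl)cccc2Cl)c2cccnc21`, 31 nM.

Both numbers come from a functional assay on HeLa cells for agonist activity at 5-hydroxytryptamine receptor 6 (Homo sapiens), read by immunoassay; on this read-out lower numbers stand for an effect already at smaller amounts and higher numbers for an effect only at larger amounts of compound. For the measured compounds named here, compound 2 holds the highest of the two numbers, yet its only neighbour is compound 1, and the step of a 1.2-fold higher number from compound 1 to compound 2 (0.09 log units; within the scatter) lies within the scatter, so the two cannot be ranked. Compound 3, `CN(C)CCn1cc(S(=O)(=O)c2ccc(Cl)s2)c2cccnc21`, is not yet measured. It differs from compound 2 by 5-chlorothiophen-2-yl in place of 2,6-dichlorophenyl on a sulfonyl sulfur. Going by the values given here, the one measured step bears on it only loosely: it shows that exchanging the group on the sulfonyl sulfur, from phenyl to 2,6-dichlorophenyl, left this assay unchanged within the scatter. Among the compounds with values here, no compound with a five-membered aromatic ring on the sulfonyl sulfur has been measured, so the step to compound 3 rests on that single comparison. Compound 3 is therefore expected to give about 35 nM, between 12 nM and 110 nM, a step of a 1.1-fold higher number from compound 2 to compound 3 (0.05 log units; within the scatter) that is expected to stay within the scatter.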

Compound 3, half-maximal effective concentration: 32 nM
For compound 3 the middle estimate is 1.1-fold (0.04 log units) above the measured one; measured number inside the range.
By their numbers in this assay, from the lowest: compounds 1, 2 and 3 (each within the scatter of the next).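

The result shows that this place on the sulfonyl sulfur also accepts a five-membered aromatic ring with one hetero atom: in this assay the exchange of 2,6-dichlorophenyl for 5-chlorothiophen-2-yl gives a 1.0-fold higher number from compound 2 to compound 3 (0.01 log units; within the scatter), and the exchange of phenyl for the same group gives a 1.3-fold higher number from compound 1 to compound 3 (0.11 log units; within the scatter). Until now, only six-membered aromatic rings of carbon had been compared here, so the reading now extends across both ring sizes, and the three compounds still cannot be ranked. Nothing at hand accounts for this lack of separation.

From the compounds shown here alone, it remains open whether a group with no aromatic ring, such as methyl or cyclohexyl, would give a number in the same range on the sulfonyl sulfur. Going by these compounds, all three compounds also share the same dimethylamine, so the reading with a primary amine in its place remains unknown.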